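Swapping thiophene for pyridine on the shared core

The source may hold more compounds than are shown below. What is called first, only, known or untested is meant among the compounds shown, and "the series" means these compounds.

Going by the values given here, compound 3 `Oc1ccc(-c2cc(-c3ccc(Cl)cc3)nc(-c3cccs3)c2)cc1` sits second highest of the three numbers so far. In a functional assay on DU-145 cells (Homo sapiens) for cytotoxicity, read by CCK-8 assay and cell counting, with a stated time of 2 days (on this read-out lower numbers stand for stronger inhibition and higher numbers for weaker inhibition), compound 3 gives 7660 nM. Compound 1 `Oc1ccc(-c2cc(-c3cccs3)nc(-c3ccccc3Cl)c2)cc1` gives 4190 nM, and the move a 1.8-fold higher number from compound 1 to compound 3 (0.26 log units; within the scatter) falls within the scatter. Among the compounds with values here, compound 2 `Oc1ccc(-c2cc(-c3cccc(Cl)c3)nc(-c3ccccn3)c2)cc1` gives 35200 nM; it differs from compound 3 in two places, so its value only shows that the one measured compound carrying pyridin-2-yl has the highest number. Compound 4 `Oc1ccc(-c2cc(-c3ccc(Cl)cc3)nc(-c3ccccn3)c2)cc1` differs from compound 3 by pyridin-2-yl in place of thiophen-2-yl on an aromatic carbon. Within the data shown here, no measured step isolates this swap, so the expectation rests on compound 2 alone. A higher number is therefore expected, roughly a 2.6-fold higher number from compound 3 to compound 4 (0.42 log units; beyond the scatter). Compound 4 is estimated at 20000 nM, between 6000 nM and 60000 nM.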

Compound 4, half-maximal inhibitory concentration: 22500 nM
The estimate for compound 4 lay 1.1-fold (0.05 log units) below the measured number; measured number inside the range.
By their numbers in this assay, from the lowest: compounds 1 and 3 (each within the scatter of the next); then compounds 4 and 2 (each within the scatter of the next).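

Pyridin-2-yl in place of thiophen-2-yl, with the 4-chlorophenyl group unchanged, gives a 2.9-fold higher number from compound 3 to compound 4 (0.47 log units; beyond the scatter) in this assay, so this swap on its own goes with modestly weaker inhibition. With pyridin-2-yl in place, 4-chlorophenyl instead of 3-chlorophenyl gives a 1.6-fold lower number from compound 2 to compound 4 (0.19 log units; within the scatter), so these two chlorine placements cannot be told apart. The data offer no explanation for either step.

Still open, going by these compounds, is how an amine or a carboxylic acid would read at the carbon next to the ring nitrogen. Also open, on these data alone, is whether pyridin-2-yl gives a similar step alongside 2-chlorophenyl.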